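Cyano to chloro on the benzyl ether

The compounds below may be only part of what the source reports. "The series", "measured", "known", "first", "only" and "open" are said of these compounds alone.

Measured in a functional assay on U-251 cells (Homo sapiens) for antiproliferative activity, read by MTT assay, with a stated time of 24 h; a higher number here means a weaker inhibitor, a lower number a stronger inhibitor:
Compound 1 `COc1cc(OC)c(-c2coc3cc(OCC=C(C)C)ccc3c2=O)cc1OC`: 3500 nM
Compound 2 `COc1cc(OC)c(-c2coc3cc(OCc4ccccc4C(F)(F)F)ccc3c2=O)cc1OC`: > 10000 nM, a limit of the assay.
Compound 3 `COc1cc(OC)c(-c2coc3cc(OCc4ccccc4C#N)ccc3c2=O)cc1OC`: 980 nM

Compound 3 holds the lower of the two exact numbers, and a 3.6-fold lower number from compound 1 to compound 3 (0.55 log units; beyond the scatter) separates it from its nearest neighbour. Compound 4 `COc1cc(OC)c(-c2coc3cc(OCc4ccc(Cl)cc4)ccc3c2=O)cc1OC` has 4-chlorophenyl in place of 2-cyanophenyl on the same saturated chain carbon: 4-chlorophenyl in place of 2-cyanophenyl on a saturated chain carbon bound to an oxygen on an aromatic ring. Among the compounds with values here, two steps bear on this change, a 3.6-fold lower number from compound 1 to compound 3 (0.55 log units; beyond the scatter) and an at least 10-fold lower number from compound 2 to compound 3 (1.00 log units; beyond the scatter). Both show that the number in this assay responds strongly to this group, and in both the 2-cyanophenyl compound has the lower number. A higher number is therefore expected, a 2.9-fold higher number from compound 3 to compound 4 (0.46 log units; beyond the scatter). For compound 4 the estimate is 2800 nM, with an expected range of 700 nM to 9000 nM.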

Compound 4, half-maximal inhibitory concentration: 470 nM
For compound 4 the middle estimate is 6.0-fold (0.78 log units) above the measured one; the whole stated range lies above it.
By their numbers in this assay, from the lowest: compound 4; then compound 3; then compound 1. At a limit, above all of these: compound 2.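

The saturated chain carbon bound to an oxygen on an aromatic ring does not need a nitrile-bearing phenyl for a low number, as 4-chlorophenyl gives a 2.1-fold lower number from compound 3 to compound 4 (0.32 log units; beyond the scatter). The same group gives a 7.4-fold lower number from compound 1 to compound 4 (0.87 log units; beyond the scatter) and an at least 21-fold lower number from compound 2 to compound 4 (1.32 log units; beyond the scatter). The second of these is only a bound, since compound 2 stands at a limit of the assay: the limit of > 10000 nM in this assay, at which 1 of the 4 values shown sits.

Because this change alters both the substituent and its printed ring position, the compounds shown leave open which of the two matters. Going by these compounds, how a phenyl ring carrying an amine or a carboxylic acid would read also remains open.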